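The source may report more compounds than this note shows. Statements on the series, on what has been measured and on what is new or still open speak of the compounds shown alone.

Measured so far in an assay (Rattus norvegicus) for inhibition of Fatty-acid amide hydrolase 1 (Homo sapiens); on this read-out higher numbers stand for weaker inhibition and lower numbers for stronger inhibition: compound 1 `NC(=O)c1cccc(-c2cnc(C(=O)CCCCCCc3ccccc3)o2)c1` gives 6 nM. Compound 2 `O=C(CCCCCCc1ccccc1)c1ncc(C(=O)C(F)(F)F)o1` gives 4 nM. Compound 3 `CN1CCN(C(=O)c2cnc(C(=O)CCCCCCc3ccccc3)o2)CC1` gives 80 nM.

Compound 3 stands highest of the three numbers; the steps of a 13-fold higher number from compound 1 to compound 3 (1.12 log units; beyond the scatter) and a 20-fold higher number from compound 2 to compound 3 (1.30 log units; beyond the scatter) both lie beyond the scatter, while a 1.5-fold lower number from compound 1 to compound 2 (0.18 log units; within the scatter) does not. Compound 4 `O=C(CCCCCCc1ccccc1)c1ncc(I)o1` differs from compound 3 as follows: iodo in place of (4-methylpiperazin-1-yl)carbonyl on an aromatic carbon. The two steps that bear on this are those reaching compound 3, both of which brought the (4-methylpiperazin-1-yl)carbonyl in with a large rise in this assay; its removal for a small substituent is therefore expected to give a large fall, back toward the values of compound 1 and compound 2. For compound 4 the expected step is an 8.0-fold lower number from compound 3 to compound 4 (0.90 log units; beyond the scatter), with an estimated value of 10 nM (range 3 nM to 40 nM).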

Compound 4, inhibition constant: 3 nM
Estimate against measurement, compound 4: 3.3-fold (0.52 log units) above; the measured number falls inside the stated range.
By their numbers in this assay, from the lowest: compounds 4, 2 and 1 (each within the scatter of the next); then compound 3.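

At this aromatic carbon next to the ring oxygen, replacing the (4-methylpiperazin-1-yl)carbonyl with a single iodine atom reverses the large rise (a 27-fold lower number from compound 3 to compound 4 (1.43 log units; beyond the scatter)). Iodo cannot be separated from the (trifluoromethyl)carbonyl (a 1.3-fold lower number from compound 2 to compound 4 (0.12 log units; within the scatter)) or the 3-carbamoylphenyl (a 2.0-fold lower number from compound 1 to compound 4 (0.30 log units; within the scatter)), so among these four compounds only compound 3 stands apart. No measurement here accounts for the difference.

Still open, going by these compounds, is whether the rise follows the basic-free carbonyl link or the ring amine itself. A carboxylic acid, a primary amide or a simple amine at this carbon would separate those readings.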